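The compounds below may be only part of what the source reports. "The series", "measured", "known", "first", "only" and "open" are said of these compounds alone.

Measured compounds:
- Compound 1 `COCc1cc(OC)c(-c2cccc3c(N(CC4CCOCC4)CC4CC4)c(C#N)nn23)c(OC)c1` gives 52 nM in an assay on HEK293 cells for displacement of a labelled ligand from corticotropin-releasing factor receptor 1 (Homo sapiens), read by scintillation counting, with a stated time of 2 h; on this read-out higher numbers stand for weaker inhibition and lower numbers for stronger inhibition.
- Compound 2 `CCc1nn2c(-c3c(OC)cc(C)cc3OC)cccc2c1N(CC1CCOCC1)CC1CC1` gives 22 nM in this assay.

Compound 2 stands at the lower of the two numbers in this assay; compound 1 sits higher, and the gap between the two lies beyond the scatter. Among the measured compounds shown here, the two structures differ in more than one place, so no single step connects them.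

Compound 3 `CCc1nn2c(-c3c(OC)cc(COC)cc3OC)cccc2c1N(CC1CCOCC1)CC1CC1` keeps the core and both flanking groups of compound 2 and differs from it in one place: methoxy in place of hydrogen on a saturated chain carbon bound to an aromatic carbon, that is, methyl to methoxymethyl. The same methoxymethyl group is present in compound 1, but compound 1 also carries a different substituent on the core, so its value cannot be read as a step from compound 2.

With no measured step of this kind in the series, the expectation for compound 3 is a small step from compound 2 in this assay, somewhat toward weaker inhibition, of a size likely within or only just beyond the scatter: a 1.4-fold higher number from compound 2 to compound 3 (0.13 log units; within the scatter). Compound 3 is estimated at 30 nM, with a range from 12 nM to 75 nM.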

Compound 3, half-maximal inhibitory concentration in the corticotropin-releasing factor receptor 1 assay: 50 nM
For compound 3 the middle estimate is 1.7-fold (0.22 log units) below the measured one; measured number inside the range.
By their numbers in the corticotropin-releasing factor receptor 1 assay, from the lowest: compound 2; then compounds 3 and 1 (each within the scatter of the next).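

In the corticotropin-releasing factor receptor 1 assay the change from methyl to methoxymethyl now has a measured size, a 2.3-fold higher number from compound 2 to compound 3 (0.36 log units; beyond the scatter), so this position accepts the added methoxy at a modest cost in binding. With methoxymethyl held fixed, ethyl in place of cyano on an aromatic carbon gives a 1.0-fold lower number from compound 1 to compound 3 (0.02 log units; within the scatter), and on this background the two core substituents cannot be told apart in the corticotropin-releasing factor receptor 1 assay. In a physicochemical assay for solubility, in phosphate buffer, measured as kinetic solubility (on this read-out lower numbers stand for lower solubility and higher numbers for higher solubility), compound 2 gives 1600 nM and compound 3 gives 4800 nM. The same change from methyl to methoxymethyl comes with higher solubility, so the position moves the two read-outs in opposite directions of usefulness: the measured solubility of compound 2, 1600 nM, and of compound 3, 4800 nM, a 3.0-fold higher number (0.48 log units; beyond the scatter)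

From the compounds shown here alone, it remains open whether a hydroxymethyl group, a longer chain such as ethoxymethyl, or an amine such as dimethylaminomethyl at this place would keep the solubility gain while returning the corticotropin-releasing factor receptor 1 assay to the level of compound 2 at 22 nM. Also open is whether the step from methyl to methoxymethyl keeps its size with cyano on the core in place of ethyl, as the only pair shown for this step carries ethyl.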